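The source may report more compounds than this note shows. Statements on the series, on what has been measured and on what is new or still open speak of the compounds shown alone.

Measured so far:
- compound 1, `COc1cc(C)cc(-c2c(-c3ccnc(-c4ccc(C(C)=O)cc4)c3)cnn2CC#N)c1` — 3350 nM 
- compound 2, `Cc1cc(O)cc(-c2nn(CC#N)cc2-c2ccnc(-c3ccc(Oc4ccccc4)cc3)c2)c1` — 1170 nM 

In a functional assay on HOP-62 cells (Homo sapiens) for inhibition, read by sulforhodamine B assay, with a stated time of 48 h (on this read-out higher numbers stand for weaker inhibition of growth and lower numbers for stronger inhibition of growth), compound 2 gives 1170 nM. Of the two measured compounds compound 2 holds the lower number, and compound 1, which gives 3350 nM in this assay, stands a distance from it that goes beyond the usual scatter. The two compounds differ in more than one place, so nothing can be said about which of those differences carries the gap; only the two numbers themselves are known.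

Compound 3, `Cc1cc(O)cc(-c2nn(CC#N)cc2-c2ccnc(-c3ccc(N(C)C)cc3)c2)c1`, is not yet measured. It keeps the shared core of compound 2 and differs from it in one place: dimethylamino in place of phenoxy on an aromatic carbon. Among the compounds with values here, no measured pair in this set separates a change of this kind on its own, so there is no step to lean on. The account therefore rests on compound 2 alone, and the step from compound 2 to compound 3 in this assay is expected to be small, within the scatter or only slightly beyond it, with no firm direction, a 1.3-fold higher number from compound 2 to compound 3 (0.11 log units; within the scatter). Compound 3 is estimated at 1500 nM in this assay, in a range from 500 nM to 4500 nM.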

Compound 3, concentration for 50% growth inhibition: 2820 nM
For compound 3 the middle estimate is 1.9-fold (0.27 log units) below the measured one, and the stated range covers the measured number.
By their numbers in this assay, from the lowest: compound 2; then compounds 3 and 1 (each within the scatter of the next).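

In this assay, within the data shown here, the exchange of phenoxy for dimethylamino on an aromatic carbon, para to a large group, gives a 2.4-fold higher number from compound 2 to compound 3 (0.38 log units; beyond the scatter), a modest step but the first comparison in the set that isolates a single place, and it shows that the group held here affects the read-out, with the phenoxy compound giving the stronger inhibition of growth. The change removes a six-membered aromatic ring of carbon only and lowers the heavy-atom count, while the counts of hydrogen-bond donors and acceptors stay the same, so the pair separates those features from the donor and acceptor counts but not from each other. No available evidence accounts for the size or direction of this step.

From the compounds shown here alone, with one exchange at this position, it remains open whether the ring, the size of the group or the atom joining it to the aromatic carbon governs the difference. Groups such as benzyloxy, piperidine or a simple methyl at this place would be needed to tell those possibilities apart, and the compounds shown do not include them.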